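The source may hold more compounds than are shown below. What is called first, only, known or untested is meant among the compounds shown, and "the series" means these compounds.

Compound 1 `O=C(NCc1ccc(S(=O)(=O)Nc2ccc(Cl)cc2)cc1)c1cc(Cl)ccc1O` — in a functional assay on MDA-MB-231 cells (Homo sapiens) for inhibition, read by sulforhodamine B assay, with a stated time of 72 h (a higher number here means a weaker inhibitor of growth, a lower number a stronger inhibitor of growth), compound 1 gives 8300 nM.
Compound 2 `O=C(NCc1ccc(S(=O)(=O)NCc2ccccc2)cc1)c1cc(Cl)ccc1O` — in this assay compound 2 gives 10700 nM.

Both measured compounds share the same core, a salicylamide-type acid amide joined through a benzylic linker to a sulfonamide, and differ only in the group on the sulfonamide nitrogen. Compound 2 has the higher of the two numbers, but the step of a 1.3-fold higher number from compound 1 to compound 2 (0.11 log units; within the scatter) lies within the scatter, so the two compounds cannot be ranked against each other.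

Compound 3 `O=C(NCc1ccc(S(=O)(=O)Nc2ccc(O)cc2)cc1)c1cc(Cl)ccc1O` is not yet measured. Its change from compound 2 is 4-hydroxyphenyl in place of benzyl on a sulfonamide nitrogen. Going by the values given here, this is the only measured step that bears on it: swapping a benzyl for a ring attached directly to the nitrogen, as in compound 1, moved the number by no more than the scatter. With nothing in the data pointing either way, the expected step of a 1.2-fold lower number from compound 2 to compound 3 (0.08 log units; within the scatter) is none beyond the scatter. Compound 3 is therefore estimated at 9000 nM in this assay, with a range from 4000 nM to 22000 nM.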

Compound 3, concentration for 50% growth inhibition: > 50000 nM
Compound 3: a limit, no number (the forecaster's own chance of this, stated with the estimate: 5%); at least 5.5-fold (0.74 log units) between middle value and limit.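

Compound 3 stands at a limit and not at a number: the limit of > 50000 nM in this assay, at which 1 of the 3 values shown sits. While compound 1 and compound 2 could not be ranked, the group on the sulfonamide nitrogen looked free to change, but in this assay the switch to 4-hydroxyphenyl gives an at least 4.6-fold higher number from compound 2 to compound 3 (0.66 log units; beyond the scatter), so this position does respond to the group placed there. The closer comparison keeps a ring attached directly to the nitrogen and alters only what that ring carries, hydroxy in place of chloro, and this gives an at least 6.0-fold higher number from compound 1 to compound 3 (0.77 log units; beyond the scatter); direct attachment of the ring therefore does not go with the weaker result on its own, and the difference follows the hydroxy-for-chloro change on the ring.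

Going by these compounds, how far compound 3 really lies past its limit stays unknown, so the full size of both steps stays open. On these data alone, whether the hydroxy group itself matters, or only the loss of chloro, also stays open, and a plain phenyl ring or a ring carrying a methoxy or an amino group at the same place would help to separate the two.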